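The source may report more compounds than this note shows. Statements on the series, on what has been measured and on what is new or still open speak of the compounds shown alone.

Measured compounds in a functional assay on MDA-MB-231 cells (Homo sapiens) for antiproliferative activity, read by MTT assay, with a stated time of 72 h; a higher number here means a weaker inhibitor, a lower number a stronger inhibitor:

Compound 1 `NC1=NC2(CCOCC2)N(OCCCOc2cccc(Cl)c2)C(N)=N1` gives 1020 nM
Compound 2 `NC1=NC2(CCSCC2)N(OCCCOc2cccc(Cl)c2Cl)C(N)=N1` gives 1 nM
Compound 3 `Cc1cc(C)cc(OCCCON2C(N)=NC(N)=NC23CCOCC3)c1` gives 3570 nM

Compound 2 has the lowest number of the three, far apart from compound 1 and compound 3. Compound 4 `NC1=NC2(CCSCC2)N(OCCCOc2cccc(Br)c2)C(N)=N1` differs from compound 2 in one place: 3-bromophenyl in place of 2,3-dichlorophenyl on an oxygen on a saturated carbon. Among the compounds with values here, no measured step changes this same pair of groups. Within the data shown here, the only measured step in this assay, a 3.5-fold higher number from compound 1 to compound 3 (0.54 log units; beyond the scatter), shows that swapping the aryl group on that oxygen shifts the number modestly. Compound 1 and compound 2 differ in two places at once, so their large gap cannot be assigned to the aryl group alone. Compound 4 is expected to give a weaker result than compound 2, by about a 30-fold higher number from compound 2 to compound 4 (1.48 log units; beyond the scatter). The estimate for compound 4 is 30 nM, within 3 nM to 300 nM.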

Compound 4, half-maximal inhibitory concentration: 60 nM
Compound 4: the middle estimate sits 2.0-fold (0.30 log units) below what was measured; low and high end bracket the measured number.
By their numbers in this assay, from the lowest: compound 2; then compound 4; then compound 1; then compound 3.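

In this assay, 3-bromophenyl in place of 2,3-dichlorophenyl gives a 60-fold higher number from compound 2 to compound 4 (1.78 log units; beyond the scatter). With the core held fixed, a change of the aryl group on this oxygen can therefore produce a large step, whereas the earlier one, a 3.5-fold higher number from compound 1 to compound 3 (0.54 log units; beyond the scatter), was modest and on a different core. Nothing available here explains the size of this step.

As far as these compounds go, this change removes one chlorine and replaces the other with bromine, so which part matters remains open. How a 3-methoxyphenyl group or a plain phenyl would behave here is also unknown.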